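Replacing a Methyl with a Benzoyl on the Side Chain

A few compounds are considered here, and "the series" means these few. Any claim that something is new, unique, unknown or untested is made for them only; others in the source may bear on it.

Of the compounds shown here, three sharing one core have been measured in a functional assay on LNCaP cells (Homo sapiens) for cytotoxicity, read by MTT assay, with a stated time of 72 h; on this read-out higher numbers stand for weaker inhibition and lower numbers for stronger inhibition. Compound 1 `Nc1ccc(Nc2c(C(=O)NCc3ccc(F)cc3)nc(Br)c3cccnc23)cc1` gives 7000 nM. Compound 2 `COC(=O)CNc1c(C(=O)NCc2ccc(F)cc2)nc(Br)c2cccnc12` gives 5000 nM. Compound 3 `CNCCCNc1c(C(=O)NCc2ccc(F)cc2)nc(Br)c2cccnc12` gives 8000 nM. Compound 3 thus carries the highest of the three numbers, yet every gap among them lies within the scatter: the step of a 1.1-fold higher number from compound 1 to compound 3 (0.06 log units; within the scatter), the step of a 1.6-fold higher number from compound 2 to compound 3 (0.20 log units; within the scatter), and the step of a 1.4-fold lower number from compound 1 to compound 2 (0.15 log units; within the scatter). Across these three compounds the group on the nitrogen attached to the aromatic ring changes widely, and the cytotoxicity read-out barely moves.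

Compound 4 `O=C(NCCCNc1c(C(=O)NCc2ccc(F)cc2)nc(Br)c2cccnc12)c1ccccc1` differs from compound 3 by benzoyl in place of methyl on an amine nitrogen. Among the compounds with values here, no measured step concerns this kind of change, an acyl group replacing a methyl on the amine nitrogen at the end of the chain. What the measured steps do show is that changing the whole group on the aromatic nitrogen, as from compound 1 to compound 2 or to compound 3, never moves the number beyond the scatter. On that basis the expected step of no change at the digits printed from compound 3 to compound 4 (within the scatter) is small, with no clear direction. In this assay compound 4 is therefore estimated at 8000 nM, with a range from 3000 nM to 20000 nM.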

Compound 4, half-maximal inhibitory concentration: > 10000 nM
Compound 4: a limit, no number (the forecaster's own chance of this, stated with the estimate: 10%); middle value at least 1.2-fold (0.09 log units) from the limit.
By their numbers in this assay, from the lowest: compounds 2, 1 and 3 (each within the scatter of the next). At a limit, above all of these: compound 4.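

In this assay compound 4 gives > 10000 nM, a limit of the assay and not a number, and the only such entry in this set: the limit of > 10000 nM in this assay, at which 1 of the 4 values shown sits. Benzoyl in place of methyl on the amine nitrogen reads as an at least 1.2-fold higher number from compound 3 to compound 4 (0.09 log units; that floor lies within the scatter), and 2-benzamidoethyl in place of methoxycarbonyl reads as an at least 2.0-fold higher number from compound 2 to compound 4 (0.30 log units; that floor lies within the scatter); both are floors that lie within the scatter, so neither step has a known size. The earlier compounds varied the whole group on the aromatic nitrogen, whereas this result concerns the far end of the side chain, where benzoyl, with its six-membered aromatic ring, gave no lower number, though a real loss can be neither shown nor ruled out.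

The compounds shown leave open how a smaller acyl group such as acetyl, or a primary amine at the end of the chain, would read in this assay. They also leave open whether benzoyl on a shorter or longer chain would give a number rather than a limit.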